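Phenyl in place of pyridin-2-yl: working notes

The compounds below may be only part of what the source reports. "The series", "measured", "known", "first", "only" and "open" are said of these compounds alone.

Measured in a physicochemical assay for solubility, in phosphate buffer, at pH 7.4 (on this read-out higher numbers stand for higher solubility and lower numbers for lower solubility), with every value a limit of the assay and not a number:
- Compound 1 `Cn1cc(C(=O)Nc2ccc(-c3cccnc3)c(C(F)(F)F)c2)c(=O)c2ccccc21` gives < 1 ug/mL
- Compound 2 `Cn1cc(C(=O)Nc2ccc(-c3ccccn3)c(C(F)(F)F)c2)c(=O)c2cnccc21` gives < 1 ug/mL
- Compound 3 `Cn1cc(C(=O)Nc2ccc(-c3ccccc3)c(C(F)(F)F)c2)c(=O)c2cccnc21` gives < 1 ug/mL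

Compound 2 stands at a limit and not at a number (< 1 ug/mL). It shares that position with the other two compounds (the limit of < 1 ug/mL in this assay, at which 3 of the 3 values shown sit). Compound 4 `Cn1cc(C(=O)Nc2ccc(-c3ccccc3)c(C(F)(F)F)c2)c(=O)c2cnccc21` has phenyl in place of pyridin-2-yl on an aromatic carbon, ortho to a trifluoromethyl group (phenyl in place of pyridin-2-yl on an aromatic carbon). For the measured compounds named here, no measured step bears on this change. Compound 3 also carries phenyl and also gives a limit (< 1 ug/mL). The expected step that the limit leaves unreadable from compound 2 to compound 4 stays within the usual scatter, with no direction expected. In this assay compound 4 is expected at 0.5 ug/mL within an estimated range of 0.2 ug/mL to 1 ug/mL and will probably report only as a limit.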

Compound 4, solubility: < 1 ug/mL
Compound 4: only a limit was reported; the forecaster's own chance of this, stated with the estimate: 85%; the middle value is on the limit's open side.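

Compound 2 and compound 4 both report only as limits, so no step can be read for phenyl in place of pyridin-2-yl. In this assay no compound shown gives a number, which leaves open whether this change moves the read-out at all.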